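A few compounds are considered here, and "the series" means these few. Any claim that something is new, unique, unknown or untested is made for them only; others in the source may bear on it.

Compound 1 `CS(=O)(=O)Nc1ccc2c(c1)S(=O)(=O)N=C(C1=C(O)C3CCCC3N(C3CCCCC3)C1=O)N2`: > 10000 nM
Compound 2 `CS(=O)(=O)Nc1ccc2c(c1)S(=O)(=O)N=C(C1=C(O)C3CCCC3N(c3ccccc3)C1=O)N2`: "not determined" (no result reported)

In an ADME assay on Huh-7 cells (Homo sapiens) for cytotoxicity, with a stated time of 72 h (on this read-out lower numbers stand for higher toxicity in this test and higher numbers for lower toxicity in this test), compound 1 reaches only > 10000 nM, which is a limit of the assay and not a number, the point described by the limit of > 10000 nM in this assay, at which 1 of the 2 values shown sits. For compound 2 this assay reports "not determined" (no result reported), so no number places it. Compound 3 `CS(=O)(=O)Nc1ccc2c(c1)S(=O)(=O)N=C(C1=C(O)C3CCCC3N(Cc3ccccc3)C1=O)N2` differs from compound 2 by benzyl in place of phenyl on an amide-type nitrogen in a ring. Among the measured compounds shown here, no measured step sets a size for this change, and no shift beyond the scatter is expected. Compound 3 is expected to give about 15000 nM, estimated between 5000 nM and 50000 nM.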

Compound 3, half-maximal cytotoxic concentration: > 33000 nM
Compound 3: only a limit was reported (the forecaster's own chance of this, stated with the estimate: 70%); at least 2.2-fold (0.34 log units) between middle value and limit.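

Compound 1 and compound 3 each carry only a limit in this assay, so the step between them, benzyl in place of cyclohexyl, cannot be read. The compounds shown leave open whether either group changes toxicity to these cells.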